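Fluoro for bromo on the aryl ring of compound 1

The source may report more compounds than this note shows. Statements on the series, on what has been measured and on what is new or still open speak of the compounds shown alone.

Compound 1 `C#CCNC(=O)/C(C)=C(\C)c1ccc(Br)cc1` is measured in a toxicity assay on the whole organism (strain Icem-CET (SPF Caw)) for cytotoxicity, with Mus musculus as the target (a lower number here means that less compound is needed, a higher number that more compound is needed for the effect), where compound 1 gives 150 mg/kg. Compound 2 `C=CCNC(=O)/C(C)=C(\C)c1ccc(Br)cc1` in this assay gives 500 mg/kg. Among the two measured numbers compound 1 holds the lowest; its nearest neighbour is compound 2, reached by a 3.3-fold higher number from compound 1 to compound 2 (0.52 log units; beyond the scatter). Among the measured compounds shown here, that step, vinyl in place of ethynyl on a saturated chain carbon bound to an amide-type nitrogen, is the only measured step.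

Compound 3 `C#CCNC(=O)/C(C)=C(\C)c1ccc(F)cc1` differs from compound 1 by fluoro in place of bromo on an aromatic carbon. For the measured compounds named here, no measured step touches the aromatic ring: the one known step alters the group on the saturated chain carbon bound to the amide-type nitrogen and gives no guidance on exchanging one halogen for another on the ring. With the shared core kept intact, the step from compound 1 to compound 3 is expected to remain within the scatter, no change at the digits printed from compound 1 to compound 3 (within the scatter). Going by the values given here, compound 3 is estimated at 150 mg/kg, with a range from 60 mg/kg to 400 mg/kg, the range kept wide since no measured step bears on this change.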

Compound 3, dose for half-maximal effect: 100 mg/kg
Compound 3: the middle estimate sits 1.5-fold (0.18 log units) above what was measured, within the range that was stated.
By their numbers in this assay, from the lowest: compounds 3 and 1 (each within the scatter of the next); then compound 2.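

In this assay, among the compounds shown here, exchanging bromo for fluoro on the aromatic carbon gives a 1.5-fold lower number from compound 1 to compound 3 (0.18 log units; within the scatter), a reading on the ring that the only other step, a 3.3-fold higher number from compound 1 to compound 2 (0.52 log units; beyond the scatter), could not supply. That other step concerns the group on the saturated chain carbon. At this position, this halogen exchange leaves the number within the scatter, so among the steps shown only ethynyl to vinyl moves it beyond the scatter. No measurement at hand accounts for the outcome of the halogen exchange or ties it to any property of either group.

From the compounds shown here alone, whether a methoxy group, a nitrile or an amine on this aromatic carbon would also keep the number within the scatter of compound 1 remains open. Also open is whether the vinyl-for-ethynyl step keeps its size with fluoro on the ring, as the compounds shown give that step only with bromo, and what a longer chain on the amide-type nitrogen would do to the number.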